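The compounds below may be only part of what the source reports. "The series", "measured", "known", "first", "only" and "open" are said of these compounds alone.

Measured so far in a functional assay on CHO-K1 cells for antagonist activity at transient receptor potential cation channel subfamily V member 1 (Homo sapiens), read by FLIPR; a higher number here means a weaker inhibitor, a lower number a stronger inhibitor:
- compound 1 `CC(C(=O)NCc1ccc(C(F)(F)F)nc1)c1ccc(NS(C)(=O)=O)c(F)c1` gives "not active" (no number reported)
- compound 2 `CC(C(=O)NCc1ccc(C(F)(F)F)nc1NC1CCCCC1)c1ccc(NS(C)(=O)=O)c(F)c1` gives 260 nM
- compound 3 `CC(C(=O)NCc1ccc(C(F)(F)F)nc1NCc1cccnc1)c1ccc(NS(C)(=O)=O)c(F)c1` gives "not active" (no number reported)

Compound 1 stands without a single number in this assay, and compound 3 likewise carries no number; only compound 2 yields a measured concentration. Going by the values given here, no step between two measured compounds is recorded for this series.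

Compound 4 `CC(C(=O)NCc1ccc(C(F)(F)F)nc1N(C)c1ccccc1)c1ccc(NS(C)(=O)=O)c(F)c1` differs from compound 1 by methyl(phenyl)amino in place of hydrogen on an aromatic carbon. Compound 2 shows that a substituent on this aromatic carbon, next to the ring nitrogen, can bring the series into a measurable range, while compound 3 shows it need not. In this assay the number for compound 4 is expected to be lower than what compound 1 would give, a step of meaningful size toward inhibition, though a result without a number remains possible. Compound 4 is estimated at 400 nM, within 100 nM to 3000 nM.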

Compound 4, half-maximal inhibitory concentration: 57.4 nM
Beside the measured number, compound 4's estimate is 7.0-fold (0.84 log units) above it; the whole stated range lies above it.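

In this assay, the change from cyclohexylamino to methyl(phenyl)amino gives a 4.5-fold lower number from compound 2 to compound 4 (0.66 log units; beyond the scatter) on this aromatic carbon next to the ring nitrogen, so the choice of amino substituent here matters beyond the scatter. Methyl(phenyl)amino has no hydrogen-bond donor, so a measured number at this position does not need one, though compound 3 gives "not active" (no number reported) with its own amino substituent. Nothing measured here accounts for the step. Still open, as far as these compounds go, is whether the methyl or the phenyl ring matters more; phenylamino and phenoxy at this carbon would separate the two.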